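Methyl on a piperidine ring, carried onto a stronger compound

A few compounds are considered here, and "the series" means these few. Any claim that something is new, unique, unknown or untested is made for them only; others in the source may bear on it.

The four compounds share one core and differ at two places. Compound 1 `COc1cc2c(Oc3ccc(NC(=O)c4nn(-c5ccccc5C)c(=O)cc4C)cc3F)ccnc2cc1OCCCN1CCCCC1` and compound 2 `COc1cc2c(Oc3ccc(NC(=O)c4nn(-c5ccccc5C)c(=O)cc4C)cc3F)ccnc2cc1OCCCN1CCC(C)CC1` are measured in a functional assay on A549 cells (Homo sapiens) for inhibition, read by MTT assay, with a stated time of 72 h; a lower number here means a stronger inhibitor, a higher number a weaker inhibitor; compound 1 gives 1920 nM and compound 2 gives 1460 nM. The change between them is methyl in place of hydrogen on a saturated ring carbon; it made a step of a 1.3-fold lower number from compound 1 to compound 2 (0.12 log units; within the scatter).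

Compound 3 `COc1cc2c(Oc3ccc(NC(=O)c4nn(-c5ccccc5OC(F)(F)F)c(=O)cc4C)cc3F)ccnc2cc1OCCCN1CCCCC1` differs from compound 1 by trifluoromethoxy in place of methyl on an aromatic carbon. In this assay compound 3 gives 120 nM, a step of a 16-fold lower number from compound 1 to compound 3 (1.20 log units; beyond the scatter), and among the three measured compounds it stands at the lowest number, beyond the scatter of the other two.

Compound 4 `COc1cc2c(Oc3ccc(NC(=O)c4nn(-c5ccccc5OC(F)(F)F)c(=O)cc4C)cc3F)ccnc2cc1OCCCN1CCC(C)CC1` is not yet measured. It differs from compound 3 by methyl in place of hydrogen on a saturated ring carbon. The place of this change is described in the same words as for the change from compound 1 to compound 2, so it is the same change, now made on the core that carries the trifluoromethoxy group.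

For compound 4 in this assay a step of a 1.2-fold lower number from compound 3 to compound 4 (0.08 log units; within the scatter) is expected, because the same change earlier gave a 1.3-fold lower number from compound 1 to compound 2 (0.12 log units; within the scatter), a step within the scatter. This rests on one earlier pair only, and whether the change reads the same on the core of compound 3 is not known. Compound 4 is estimated at 100 nM, with the range 50 nM to 220 nM.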

Compound 4, half-maximal inhibitory concentration: 90 nM
The estimate for compound 4 lay 1.1-fold (0.05 log units) above the measured number; low and high end bracket the measured number.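

In this assay, methyl in place of hydrogen on a saturated ring carbon, which turns piperidin-1-yl into 4-methylpiperidin-1-yl, gave a 1.3-fold lower number from compound 3 to compound 4 (0.12 log units; within the scatter), and this step reads the same as on the core of compound 1: the same change on two cores in this assay, a 1.3-fold lower number (0.12 log units; within the scatter) from compound 1 to compound 2 and a 1.3-fold lower number (0.12 log units; within the scatter) from compound 3 to compound 4, 1.0-fold (0.01 log units) apart, within the scatter of two such steps. Trifluoromethoxy in place of methyl on an aromatic carbon gave a 16-fold lower number from compound 2 to compound 4 (1.21 log units; beyond the scatter), and this large step also carried over unchanged whether or not the methyl was present: the same change on two cores in this assay, a 16-fold lower number (1.20 log units; beyond the scatter) from compound 1 to compound 3 and a 16-fold lower number (1.21 log units; beyond the scatter) from compound 2 to compound 4, 1.0-fold (0.01 log units) apart, within the scatter of two such steps. Across these four compounds each change therefore reads the same with or without the other, but the methyl step stays within the scatter on both cores, so this shows only that a step too small to read stayed that way, not that the methyl lowers the number, and two pairs in one cell assay say nothing about other cores.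

The compounds shown leave open whether a morpholin-4-yl or a dimethylamino group in place of piperidin-1-yl, or a longer chain carrying the amine, would behave the same way on both cores. Going by these compounds, it also remains open whether a chloro or an ethoxy group in place of trifluoromethoxy would give a step of similar size.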